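This account rests on a few compounds, and the source may have more. Where it says the series, first, only, none or still open, it means among the compounds named here.

In a functional assay on A549 cells (Homo sapiens) for antiproliferative activity, read by MTT assay, with a stated time of 72 h (a lower number here means a stronger inhibitor, a higher number a weaker inhibitor), compound 1 (`CC(C)N1C(=O)COc2ccc(-c3cccc(NS(=O)(=O)c4ccc(F)cc4)c3)cc21`) gives 29400 nM as a measured number. Compound 2 (`O=C1COc2ccc(-c3cccc(NS(=O)(=O)c4ccc(F)cc4)c3)cc2N1c1ccccc1`) stands at > 40000 nM as a limit of the assay, not a number. Going by the values given here, the one measured step (an at least 1.3-fold higher number from compound 1 to compound 2 (0.13 log units; that floor lies within the scatter)) gives only a floor, and that floor lies within the scatter. Compound 3 (`O=C1COc2ccc(-c3cccc(NS(=O)(=O)c4ccc(F)cc4)c3)cc2N1C1CC1`) differs from compound 2 by cyclopropyl in place of phenyl on an amide-type nitrogen in a ring with cyclopropyl in place of phenyl on an amide-type nitrogen in a ring. On that step alone, a small move to a lower number is expected, towards compound 1 at 29400 nM as the nearest measured reference. The expected step is an at least 1.4-fold lower number from compound 2 to compound 3 (0.15 log units; that floor lies within the scatter) in size. Compound 3 is estimated at 28000 nM within a range from 12000 nM to 45000 nM in this assay for now.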

Compound 3, half-maximal inhibitory concentration: > 40000 nM
Compound 3 ended at the assay's limit; the forecaster's own chance of this, stated with the estimate: 35%; middle value at least 1.4-fold (0.15 log units) away from the limit.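

In this assay, compound 3 gives > 40000 nM, a limit of the assay and not a number, so swapping phenyl for the smaller cyclopropyl on the amide-type nitrogen in a ring does not yield a measured value. Against the isopropyl of compound 1, the change gives an at least 1.3-fold higher number from compound 1 to compound 3 (0.13 log units; that floor lies within the scatter). The step between compound 2 and compound 3 cannot be read, and compound 1 remains the only one of the three with a measured number: the limit of > 40000 nM in this assay, at which 2 of the 3 values shown sit.

Still open, on these data alone, is whether any group on this nitrogen can give a clearly lower number than compound 1. A longer chain ending in an amine or a carboxylic acid would test this.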